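The source may hold more compounds than are shown below. What is called first, only, known or untested is meant among the compounds shown, and "the series" means these compounds.

Measured so far in an ADME assay on HEK-293T cells (Homo sapiens) for cytotoxicity, read by MTT assay, with a stated time of 24 h; a lower number here means that less compound is tolerated, a higher number that more compound is tolerated
- Compound 1 `Cc1ccc(C)c(S(=O)(=O)n2c(-c3cn(-c4ccccc4)nc3-c3ccc(F)cc3)nc3ccccc32)c1` gives 54200 nM
- Compound 2 `O=S(=O)(c1ccc(Br)cc1)n1c(-c2cn(-c3ccccc3)nc2-c2ccc(F)cc2)nc2ccccc21` gives 239000 nM

Compound 1 stands lowest of these two numbers. Compound 3 `Cc1ccc(C)c(S(=O)(=O)n2c(-c3cn(-c4ccccc4)nc3-c3ccc(C(F)(F)F)cc3)nc3ccccc32)c1` differs from it in one place, with trifluoromethyl in place of fluoro on an aromatic carbon. Going by the values given here, the only measured step, a 4.4-fold higher number from compound 1 to compound 2 (0.64 log units; beyond the scatter) in this assay, is modest and lies on a sulfonyl sulfur, elsewhere in the molecule. It therefore offers little guidance, and no change at the fluoro position has been measured. No step beyond the scatter is expected, and the direction is open, so the expected step is small (a 1.1-fold higher number from compound 1 to compound 3 (0.04 log units; within the scatter)). Compound 3 is estimated at 60000 nM (expected range 20000 nM to 180000 nM).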

Compound 3, half-maximal cytotoxic concentration: 223000 nM
For compound 3 the middle estimate is 3.7-fold (0.57 log units) below the measured one, and the stated range ends below it.
By their numbers in this assay, from the lowest: compound 1; then compounds 3 and 2 (each within the scatter of the next).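

Trifluoromethyl in place of fluoro gives a 4.1-fold higher number from compound 1 to compound 3 (0.61 log units; beyond the scatter) in this assay and so shows that the para group on this six-membered aromatic ring is not a silent position. A change here, and not only one on the sulfonyl sulfur, can move the number beyond the scatter, towards more compound being tolerated. Nothing measured here explains why the number moves.

The compounds shown leave open how an amine, a methoxy group or a chlorine atom at this position would behave. They also leave open whether the same swap would give a similar step with the 4-bromophenyl group on the sulfonyl sulfur.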